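The source may hold more compounds than are shown below. What is called first, only, known or untested is meant among the compounds shown, and "the series" means these compounds.

Working notes on the series, which is followed in a functional assay on UACC-62 cells (Homo sapiens) for inhibition, read by sulforhodamine B assay, with a stated time of 48 h; a lower number here means a stronger inhibitor of growth, a higher number a weaker inhibitor of growth.

Compound 1 `N#C/C(=C\c1c(-c2ccccc2)[nH]c2ccccc12)C(=O)c1ccccc1` gives 3600 nM in this assay, the higher of the two numbers recorded so far. Among the measured compounds shown here, compound 2 `COc1ccc(-c2[nH]c3ccc(OC)cc3c2C=C(C#N)C#N)cc1` gives 357 nM in this assay, a number lower than that of compound 1 and beyond the scatter; compound 2 differs from compound 1 in more than one place, so the two values show only where each stands and allow no single step to be read.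

Compound 3 `N#C/C(=C\c1c(-c2ccccc2)[nH]c2ccccc12)S(=O)(=O)c1ccccc1` is not yet measured in this assay. It differs from compound 1 by phenylsulfonyl in place of benzoyl on a double-bonded chain carbon bound to a double-bonded chain carbon and a triple-bonded carbon. For the measured compounds named here, no measured pair shows a change of this kind, so there is no recorded step on which to base a direction. The step from compound 1 to compound 3 is therefore expected to be a 1.2-fold lower number from compound 1 to compound 3 (0.08 log units; within the scatter), none beyond the scatter. For compound 3 the estimate in this assay is 3000 nM, within a range of 800 nM to 12000 nM.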

Compound 3, concentration for 50% growth inhibition: 2600 nM
For compound 3 the middle estimate is 1.2-fold (0.06 log units) above the measured one; low and high end bracket the measured number.
By their numbers in this assay, from the lowest: compound 2; then compounds 3 and 1 (each within the scatter of the next).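

In this assay, among the compounds shown here, phenylsulfonyl in place of benzoyl on a double-bonded chain carbon bound to a double-bonded chain carbon and a triple-bonded carbon gives the first step that can be read: a 1.4-fold lower number from compound 1 to compound 3 (0.14 log units; within the scatter). This position therefore accepts either group with no change in growth inhibition beyond the scatter, and the aromatic ring of carbon only is present on both sides of the change. No measurement bears on why the two groups read alike here.

From the compounds shown here alone, whether an amine, a carboxylic acid or a longer chain at this position would hold the number or move it remains open. Compound 2 differs from compound 1 and compound 3 in more than one place, so those comparisons cannot be read as steps, and which of its changes goes with its lower number is unresolved.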